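A few compounds are considered here, and "the series" means these few. Any claim that something is new, unique, unknown or untested is made for them only; others in the source may bear on it.

Measured compounds:
- compound 1, `Cc1nc(C#N)c(N)c2c1C(=O)N(Cc1ccccc1)C2=O`: < 5000 nM
- compound 2, `Cc1noc(-c2nc(C)c3c(c2N)C(=O)N(Cc2ccc(Oc4ccc(F)cc4)cc2)C3=O)n1`: 23800 nM

The account concerns two measured compounds and one that awaits measurement in a physicochemical assay for solubility, using the shake flask method, in simulated intestinal fluid, measured as kinetic solubility, with a stated time of 2 h, at 25 degrees C, at pH 6.5; on this read-out lower numbers stand for lower solubility and higher numbers for higher solubility. Compound 1, `Cc1nc(C#N)c(N)c2c1C(=O)N(Cc1ccccc1)C2=O`, gives < 5000 nM in this assay, and this is a limit of the assay rather than a number. Going by the values given here, compound 2, `Cc1noc(-c2nc(C)c3c(c2N)C(=O)N(Cc2ccc(Oc4ccc(F)cc4)cc2)C3=O)n1`, gives 23800 nM in this assay, the only number reported among the two. The other value, that of compound 1, is a limit of the assay, as stated in the limit of < 5000 nM in this assay, at which 1 of the 2 values shown sits.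

Compound 3, `Cc1noc(-c2nc(C)c3c(c2N)C(=O)N(Cc2ccc(OC(F)F)cc2)C3=O)n1`, is not yet measured. It differs from compound 2 by difluoromethyl in place of 4-fluorophenyl on an oxygen on an aromatic ring.

Among the compounds with values here, no step between measured compounds is available, so the size of this change cannot be read from any pair already in hand. Within the data shown here, the expectation for compound 3 rests on compound 2 alone, whose value 23800 nM is the only number given. Compound 3 is expected to move upward from compound 2 by a 2.9-fold higher number from compound 2 to compound 3 (0.47 log units; beyond the scatter), a step beyond the usual scatter. Compound 3 is therefore estimated at 70000 nM in this assay, with a range from 20000 nM to 250000 nM.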

Compound 3, solubility: < 5000 nM
Compound 3: no number, only a limit (the forecaster's own chance of this, stated with the estimate: 10%); middle value at least 14-fold (1.14 log units) from the limit.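

In this assay compound 3 gives < 5000 nM, which is a limit of the assay and not a number. Even so, this is the first reading of what a change at this position can do: difluoromethyl in place of 4-fluorophenyl on an oxygen on an aromatic ring gives an at least 4.7-fold lower number from compound 2 to compound 3 (0.67 log units; beyond the scatter), so the step is real in its direction and known only as a minimum in its size. Of this pair, only the compound carrying 4-fluorophenoxy gives a number, and compound 3 joins compound 1 at the same limit: the limit of < 5000 nM in this assay, at which 2 of the 3 values shown sit.

Going by these compounds, how far compound 3 lies under its limit stays open, and a single pair cannot separate the loss of the aromatic ring from the entry of difluoromethyl itself. Also open, on these data alone, is what an amine, a carboxylic acid or a longer chain on that oxygen would give, and whether the same change would act in the same way on the core of compound 1.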